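The source may hold more compounds than are shown below. What is called first, only, known or untested is meant among the compounds shown, and "the series" means these compounds.

Measured so far in an ADME assay on MDBK cells (Bos taurus) for cytotoxicity; a higher number here means that more compound is tolerated, a lower number that less compound is tolerated:
- compound 1 `Clc1ccccc1Cn1ccc2nc(-c3ccccc3)nc-2c1`: > 100000 nM (a limit)
- compound 2 `Clc1cccc(Cn2ccc3nc(-c4ccccc4)nc-3c2)c1`: > 100000 nM (a limit)
- compound 3 `Brc1ccc(Cn2ccc3nc(-c4ccccc4)nc-3c2)cc1`: 83000 nM

Among the measured compounds shown here, compound 3, at 83000 nM, holds the only actual number in the set. The rest of the data is thin: the limit of > 100000 nM in this assay, at which 2 of the 3 values shown sit.

Compound 4 `Clc1ccc(Cn2ccc3nc(-c4ccccc4)nc-3c2)cc1Cl` carries 3,4-dichlorophenyl in place of 4-bromophenyl on a saturated chain carbon bound to an aromatic nitrogen.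

For the measured compounds named here, two measured steps bear on this change, an at least 1.2-fold lower number from compound 1 to compound 3 (0.08 log units; that floor lies within the scatter) and an at least 1.2-fold lower number from compound 2 to compound 3 (0.08 log units; that floor lies within the scatter). Each gives only a floor, and both floors lie within the scatter. a step that the two limits leave unreadable from compound 1 to compound 2 adds nothing readable.

In this assay, the expected outcome is a 1.2-fold lower number from compound 3 to compound 4 (0.06 log units; within the scatter), with no change expected beyond the scatter.

For compound 4 the estimated value is 72000 nM, with an expected range of 35000 nM to 100000 nM.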

Compound 4, half-maximal cytotoxic concentration: 71000 nM
The estimate for compound 4 lay 1.0-fold (0.01 log units) above the measured number; measured number inside the range.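

In this assay, 3,4-dichlorophenyl on a saturated chain carbon bound to an aromatic nitrogen adds a second actual number to the series, and the exchange for 4-bromophenyl gives a 1.2-fold lower number from compound 3 to compound 4 (0.07 log units; within the scatter). Against the chlorophenyl compounds, the data give an at least 1.4-fold lower number from compound 2 to compound 4 (0.14 log units; that floor lies within the scatter) and an at least 1.4-fold lower number from compound 1 to compound 4 (0.14 log units; that floor lies within the scatter). These two steps remain floors because of the limit: the limit of > 100000 nM in this assay, at which 2 of the 4 values shown sit.

Still open, on these data alone, is whether an amine or a carboxylic acid in place of the chloro groups of 3,4-dichlorophenyl would give a step beyond the scatter. As far as these compounds go, a longer chain at this position is equally open.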